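Working notes: bromo in place of hydrogen, compound 4

The source may hold more compounds than are shown below. What is called first, only, known or untested is meant among the compounds shown, and "the series" means these compounds.

In a functional assay on MDA-MB-231 cells (Homo sapiens) for antiproliferative activity, read by sulforhodamine B assay, with a stated time of 48 h (on this read-out lower numbers stand for stronger inhibition and higher numbers for weaker inhibition), compound 1 (`COc1ccc2nc(-c3ccc(N/C=C\C(=O)c4cc(OC)c(OC)c(OC)c4)c(C)c3)sc2c1`) gives 17000 nM. Compound 2 (`COc1ccc2nc(-c3ccc(N/C=C\C(=O)c4cc(OC)c(OC)c(OC)c4)cc3)sc2c1`) gives 19600 nM, and compound 3 (`COc1cc(C(=O)/C=C\Nc2ccc(-c3nc4cc(OC)c(OC)c(OC)c4s3)cc2)cc([N+](=O)[O-])c1OC`) gives 9800 nM. The numbers for compound 2 and compound 3 both lie within the scatter of the number for compound 1, so compound 1 has no clear standing in this small set.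

Compound 4 (`COc1ccc2nc(-c3ccc(N/C=C\C(=O)c4cc(OC)c(OC)c(OC)c4Br)c(C)c3)sc2c1`) is compound 1 with bromo in place of hydrogen on an aromatic carbon. For the measured compounds named here, one measured step bears on this only indirectly. Hydrogen in place of methyl on an aromatic carbon gives a 1.2-fold higher number from compound 1 to compound 2 (0.06 log units; within the scatter), at a different place in the molecule. Compound 3 differs from compound 1 in more than one place, so it offers no single-change comparison. Going by the values given here, no measured compound carries bromo, and the data do not show how this assay responds to a change at this carbon.

No step beyond the scatter is therefore expected, and no direction is favoured with any confidence, though the uncertainty is wide. The expected step is a 1.1-fold lower number from compound 1 to compound 4 (0.05 log units; within the scatter). For compound 4 the estimated value is 15000 nM, with an expected range from 5000 nM to 40000 nM.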

Compound 4, half-maximal inhibitory concentration: 9400 nM
Beside the measured number, compound 4's estimate is 1.6-fold (0.20 log units) above it, within the range that was stated.
By their numbers in this assay, from the lowest: compounds 4, 3, 1 and 2 (each within the scatter of the next, the first and the last beyond it).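

For the compounds shown here, this carbon of the six-membered aromatic ring of carbon only, ortho to a large group and ortho to a methoxy group, had no single-change comparison until compound 4; the only earlier step, a 1.2-fold higher number from compound 1 to compound 2 (0.06 log units; within the scatter), lay at a different place in the molecule. In this assay, the step for bromo in place of hydrogen is a 1.8-fold lower number from compound 1 to compound 4 (0.26 log units; within the scatter), so this carbon accepts one bromine atom without a change beyond the scatter, and the compound 1 scaffold retains measurable antiproliferative activity with the ring carrying bromo alongside its three methoxy groups. No measurement available here accounts for the size or direction of this step.

On these data alone, a single substitution at this carbon cannot show how the assay responds to the position in general, so it remains open whether an amine, a carboxylic acid or a longer chain in place of bromo would give a step beyond the scatter. Also open, as far as these compounds go, is whether bromo at this carbon gives a similar step on compound 2, which has hydrogen in place of the methyl group.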